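A few compounds are considered here, and "the series" means these few. Any claim that something is new, unique, unknown or untested is made for them only; others in the source may bear on it.

Working notes on a small set of analogues built on one shared core.

Compound 1 `O=C(/C=C\Nc1ccc(O)cc1)c1cn(-c2ccccc2)nc1-c1ccccc1` is the reference point. In an ADME assay on HaCaT cells (Homo sapiens) for antiproliferative activity, read by MTT assay, with a stated time of 48 h (a higher number here means a weaker inhibitor, a lower number a stronger inhibitor), compound 1 gives 44600 nM. Compound 2 `COc1ccc(N/C=C\C(=O)c2cn(-c3ccccc3)nc2-c2ccccc2)cc1` reaches only a limit of the assay rather than a number: in this assay compound 2 gives > 50000 nM. Compound 3 `COc1ccc(-c2nn(-c3ccccc3)cc2C(=O)/C=C\Nc2ccc(O)cc2)cc1` is the third measured member, and in this assay compound 3 gives 34600 nM.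

Compound 2 differs from compound 1 by methyl in place of hydrogen on an oxygen on an aromatic ring. The measured step is an at least 1.1-fold higher number from compound 1 to compound 2 (0.04 log units; that floor lies within the scatter); its true size is not known, since compound 2 sits at the limit of > 50000 nM in this assay, at which 1 of the 3 values shown sits. Compound 3 differs from compound 1 by methoxy in place of hydrogen on an aromatic carbon, which is also how the core of compound 3 differs from the core of compound 1; the step there is a 1.3-fold lower number from compound 1 to compound 3 (0.11 log units; within the scatter).

Compound 4 `COc1ccc(N/C=C\C(=O)c2cn(-c3ccccc3)nc2-c2ccc(OC)cc2)cc1` has not yet been measured. It differs from compound 3 by methyl in place of hydrogen on an oxygen on an aromatic ring. Among the compounds with values here, this is the same change as the one from compound 1 to compound 2, made at a place described in the same words, so it appears twice in the set. For the step from compound 3 to compound 4 the expectation is a 1.6-fold higher number from compound 3 to compound 4 (0.20 log units; within the scatter), which rests on an at least 1.1-fold higher number from compound 1 to compound 2 (0.04 log units; that floor lies within the scatter) and on compound 2 having reached (the limit of > 50000 nM in this assay, at which 1 of the 3 values shown sits), so a limit is again a likely outcome. Compound 4 is therefore expected at 55000 nM. The expected range for compound 4 runs from 28000 nM to 120000 nM.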

Compound 4, half-maximal inhibitory concentration: > 50000 nM
Compound 4: only a limit was reported (the forecaster's own chance of this, stated with the estimate: 60%); the middle value does not contradict the limit.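

Going from hydroxy to methoxy on the 4-hydroxyphenyl group in this assay gives an at least 1.4-fold higher number from compound 3 to compound 4 (0.15 log units; that floor lies within the scatter), and the comparison with the same change on the other core reads: the same change on two cores in this assay, an at least 1.1-fold higher number (0.04 log units; that floor lies within the scatter) from compound 1 to compound 2 and an at least 1.4-fold higher number (0.15 log units; that floor lies within the scatter) from compound 3 to compound 4; the limit leaves it open whether they differ

Both floors point the same way and both methoxy products are reported only as limits, so the two cores do not contradict each other, but each floor lies within the scatter and neither step has a known true size, which means the data show neither a transfer of equal size nor a real loss on either core: the limit of > 50000 nM in this assay, at which 2 of the 4 values shown sit.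

The step between the two compounds that end as limits cannot be read, so the methoxy on the aromatic carbon tells nothing further once the oxygen on the other ring carries methyl.

The compounds shown leave open how large this change really is, which would take a pair in which both members give a number rather than a limit. They also leave open how the hydroxy would compare with an amine or a carboxylic acid at the same place, or with an ethyl or longer chain on that oxygen in place of methyl.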